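A few compounds are considered here, and "the series" means these few. Any claim that something is new, unique, unknown or untested is made for them only; others in the source may bear on it.

Compound 1 `NC(=O)c1c(NC(=O)c2ccccc2Cl)sc2c1CCN(Cc1ccccc1Cl)C2` gives 4430 nM in a functional assay on MKN-74 cells (Homo sapiens) for antiproliferative activity, with a stated time of 24 h (a higher number here means a weaker inhibitor, a lower number a stronger inhibitor), the highest of the two numbers recorded; its nearest neighbour, compound 2 `NC(=O)c1c(NC(=O)c2ccccc2Cl)sc2c1CCN(C(=S)Nc1c(Cl)cccc1Cl)C2`, gives 4020 nM. Among the compounds with values here, the only measured step, a 1.1-fold lower number from compound 1 to compound 2 (0.04 log units; within the scatter), also replaces the group on the amine nitrogen in a ring with a thiourea and stays within the scatter. Compound 3 `NC(=O)c1c(NC(=O)c2ccccc2Cl)sc2c1CCN(C(=S)Nc1cccnc1)C2` differs from compound 1 by a group of 9 heavy atoms (6 carbon, 2 nitrogen, 1 sulfur; one six-membered aromatic ring with 1 hetero atom) in place of a group of 8 heavy atoms (7 carbon, 1 chlorine; one six-membered aromatic ring of carbon only), on an amine nitrogen in a ring. Since that one related step was flat, no change beyond the scatter is expected, a 1.1-fold higher number from compound 1 to compound 3 (0.05 log units; within the scatter). Compound 3 is therefore estimated at 5000 nM, between 2000 nM and 12500 nM.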

Compound 3, half-maximal inhibitory concentration: 38600 nM
For compound 3 the middle estimate is 7.7-fold (0.89 log units) below the measured one; the measured number lies above the stated range.
By their numbers in this assay, from the lowest: compounds 2 and 1 (each within the scatter of the next); then compound 3.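

In this assay the group on the amine nitrogen in a ring proves not to be indifferent: the pyridin-3-yl thiourea brings an 8.7-fold higher number from compound 1 to compound 3 (0.94 log units; beyond the scatter) at this position. Pyridin-3-yl in place of 2,6-dichlorophenyl on an amide-type nitrogen gives a 9.6-fold higher number from compound 2 to compound 3 (0.98 log units; beyond the scatter) within the thiourea series, so the thiourea alone does not carry the loss and the aromatic group on it matters. No evidence bears on the cause of this step. The compounds shown leave open whether the ring nitrogen of the pyridine or the missing chlorines decide the outcome, which an unsubstituted phenyl on the same thiourea would separate.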